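A few compounds are considered here, and "the series" means these few. Any claim that something is new, unique, unknown or untested is made for them only; others in the source may bear on it.

Working notes on the series. In a functional assay on HeLa cells (Homo sapiens) for antiproliferative activity, read by MTT assay, with a stated time of 48 h (a higher number here means a weaker inhibitor, a lower number a stronger inhibitor), compound 1 `COc1cccc(-c2nn(-c3ccccc3)cc2C(Nc2nc3ccccc3s2)c2c(O)ccc3ccccc23)c1` gives 14900 nM, compound 2 `COc1ccc2nc(NC(c3cn(-c4ccccc4)nc3-c3ccc(F)cc3)c3c(O)ccc4ccccc34)sc2c1` gives 4630 nM and compound 3 `COc1ccc2nc(NC(c3cn(-c4ccccc4)nc3-c3cccc([N+](=O)[O-])c3)c3c(O)ccc4ccccc34)sc2c1` gives 6140 nM. Compound 3 lies within the scatter of compound 2, while compound 1 carries a higher number than compound 3, beyond the scatter.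

Compound 4 `COc1cccc(-c2nn(-c3ccccc3)cc2C(Nc2nc3ccc(OC)cc3s2)c2c(O)ccc3ccccc23)c1` follows from compound 3 by one change, methoxy in place of nitro on an aromatic carbon, so 3-nitrophenyl becomes 3-methoxyphenyl. Going by the values given here, the only measured step at this aryl group is a 1.3-fold higher number from compound 2 to compound 3 (0.12 log units; within the scatter), which gives no sign of a large effect from exchanging it. Compound 1 shares the 3-methoxyphenyl with compound 4 but lacks its further methoxy group, and compound 1 at 14900 nM tilts the expectation slightly towards a higher number. No step beyond the scatter is therefore expected in this assay. The estimated step is a 1.2-fold higher number from compound 3 to compound 4 (0.09 log units; within the scatter). For compound 4 the estimated value is 7500 nM, with an expected range from 3800 nM to 14000 nM.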

Compound 4, half-maximal inhibitory concentration: 10500 nM
Estimate against measurement, compound 4: 1.4-fold (0.15 log units) below; the range from low to high includes it.
By their numbers in this assay, from the lowest: compounds 2, 3, 4 and 1 (each within the scatter of the next, the first and the last beyond it).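

In this assay, going by these compounds alone, methoxy in place of nitro on an aromatic carbon gives a 1.7-fold higher number from compound 3 to compound 4 (0.23 log units; within the scatter) and so does not separate the two groups at this position, while 3-methoxyphenyl in place of 4-fluorophenyl gives a 2.3-fold higher number from compound 2 to compound 4 (0.36 log units; beyond the scatter) as the first modest step at this aryl group to pass the scatter. That step alters both the substituent and its place on the ring, so it cannot assign the difference to either one. Methoxy in place of hydrogen on the other part of the core gives a 1.4-fold lower number from compound 1 to compound 4 (0.15 log units; within the scatter) as a first reading at that place, and nothing available bears on why these steps take the sizes they do.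

Open, on these data alone, is whether an amine or a carboxylic acid on this phenyl ring would give a step beyond the scatter. Also open, as far as these compounds go, is whether 3-fluorophenyl would separate the effect of the group from that of its place on the ring.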